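Adding a Fluoro to the Phenyl of Compound 3

The source may report more compounds than this note shows. Statements on the series, on what has been measured and on what is new or still open speak of the compounds shown alone.

Compound 3 `Cc1nc(-c2ccccc2)c(C(=O)N2CCN(c3ccccc3)CC2)o1` gives 39.1 nM in a functional assay on HL-60 cells (Homo sapiens) for inhibition, read by MTT assay, with a stated time of 72 h (on this read-out lower numbers stand for stronger inhibition and higher numbers for weaker inhibition), the second highest of three numbers. Compound 2 `Cc1nc(-c2ccccc2)c(C(=O)N2CCN(c3cccc(C)c3C)CC2)o1` gives 35 nM, and a 1.1-fold higher number from compound 2 to compound 3 (0.05 log units; within the scatter), so these two stand together. Compound 1 `Cc1nc(-c2ccccc2)c(C(=O)N2CCN(c3cccc(C(F)(F)F)c3)CC2)o1` gives 153 nM; here a 3.9-fold lower number from compound 1 to compound 3 (0.59 log units; beyond the scatter), and likewise a 4.4-fold lower number from compound 1 to compound 2 (0.64 log units; beyond the scatter). Compound 4 `Cc1nc(-c2ccccc2)c(C(=O)N2CCN(c3cccc(F)c3)CC2)o1` is compound 3 with fluoro in place of hydrogen on an aromatic carbon. The step from compound 1 to compound 3 is the only measured one touching this position, and it removed trifluoromethyl; fluoro, not trifluoromethyl, now enters there, so that step is only a loose guide. A change within the scatter is therefore expected, a 1.3-fold higher number from compound 3 to compound 4 (0.11 log units; within the scatter). Compound 4 is estimated at 50 nM, with a range from 20 nM to 130 nM.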

Compound 4, half-maximal inhibitory concentration: 45 nM
Estimate against measurement, compound 4: 1.1-fold (0.05 log units) above; low and high end bracket the measured number.
By their numbers in this assay, from the lowest: compounds 2, 3 and 4 (each within the scatter of the next); then compound 1.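

Putting fluoro on this aromatic carbon leaves the result within the scatter, with a 1.2-fold higher number from compound 3 to compound 4 (0.06 log units; within the scatter), and 3-fluorophenyl also stands level with 2,3-dimethylphenyl, with a 1.3-fold higher number from compound 2 to compound 4 (0.11 log units; within the scatter). So this carbon tolerates a single fluoro, while the weaker result belongs to trifluoromethyl rather than to any group placed here, with a 3.4-fold lower number from compound 1 to compound 4 (0.53 log units; beyond the scatter). Nothing available explains this difference between fluoro and trifluoromethyl.

From the compounds shown here alone, it remains open whether chloro, methoxy or an amine at this carbon would match fluoro or trifluoromethyl. Going by these compounds, the effect of fluoro on other carbons of this ring also remains open.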